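The source may hold more compounds than are shown below. What is called first, only, known or untested is meant among the compounds shown, and "the series" means these compounds.

Compound 1 `N#CC1=C(NCC(=O)O)N(c2ccccc2)C(=O)N2CCCCC(N3CCCC3)C12` gives 81.7%.
Compound 2 `N#CC1=C(/N=C/c2ccccc2)N(c2ccccc2)C(=O)N2CCCCC(N3CCCC3)C12` gives 75.9%.

In a functional assay on the whole organism (strain albino) for inhibition, with Rattus norvegicus as the target, read by paw edema, with stated times of 1 h and 2 h, at a dose of 20 mmol/kg by the intraperitoneal route (on this read-out higher numbers stand for more inhibition at the one dose given (going by the name of the read-out) and lower numbers for less inhibition), compound 2 stands at 75.9%, while compound 1 stands at 81.7%; the two numbers lie within the scatter of each other, so the inhibition in this assay is level between them. Among the measured compounds shown here, the single measured step, a number 5.8 percentage points lower from compound 1 to compound 2 (within the scatter), concerns the group on the double-bonded ring carbon and not the six-membered aromatic ring of carbon only that is altered next. Compound 3 `COc1ccc(/C=N/C2=C(C#N)C3C(N4CCCC4)CCCCN3C(=O)N2c2ccccc2)cc1` differs from compound 2 at that ring: methoxy in place of hydrogen on an aromatic carbon, the phenyl becoming 4-methoxyphenyl. For the measured compounds named here, no measured pair in this set touches that ring, so the only guide is the one step seen, which stayed within the scatter even for an exchange of whole groups. The change to compound 3 is estimated as a number 0.9 percentage points lower from compound 2 to compound 3 (within the scatter), with no shift beyond the scatter anticipated in either direction. The estimate for compound 3 in this assay is 75%, expected to fall between 62% and 88%.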

Compound 3, a percentage reported as inhibition, in the whole organism at one dose (the size of the read-out at that dose, not a potency): 71.6%
Beside the measured number, compound 3's estimate is 3.4 percentage points above it; measured number inside the range.
By their numbers in this assay, from the lowest: compounds 3, 2 and 1 (each within the scatter of the next, the first and the last beyond it).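

Among the compounds shown here, the first measured change on the aromatic ring itself, methoxy in place of hydrogen on an aromatic carbon para to a large group, gives a number 4.3 percentage points lower from compound 2 to compound 3 (within the scatter) in this assay, so phenyl and 4-methoxyphenyl read as level at this position. For the compounds shown here, measured against compound 1, however, the larger group on the double-bonded ring carbon gives a number 10.1 percentage points lower from compound 1 to compound 3 (beyond the scatter), the only step in this set beyond the scatter, and a modest one, while compound 2 stays within the scatter of both compound 1 and compound 3. Nothing available explains either step, so the numbers stand here as observations alone.

What the compounds shown leave open is whether this aromatic carbon stays as undemanding with a different kind of group, such as an amine, a hydroxyl or a chlorine, in place of the methoxy. Also open, as far as these compounds go, is whether a longer chain, such as butoxy, would stay level with compound 2 or would widen the distance from compound 1.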